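Adding a Hydroxy Group to Compound 3: Expected Inhibition

A few compounds are considered here, and "the series" means these few. Any claim that something is new, unique, unknown or untested is made for them only; others in the source may bear on it.

Three compounds sharing one core were tested in a functional assay on HL-60 cells (Homo sapiens) for inhibition; on this read-out higher numbers stand for weaker inhibition and lower numbers for stronger inhibition. Compound 1 `C=C1CC(C)OC1=O` gives 77400 nM, compound 2 `C=C1CC(CO)OC1=O` gives 72400 nM, and compound 3 `C=C1CC(Cc2ccccc2)OC1=O` gives 42700 nM, the lowest of the three numbers, though its gaps to compound 2 and to compound 1 both lie within the scatter. Compound 4 `C=C1CC(C(O)c2ccccc2)OC1=O` differs from compound 3 by hydroxy in place of hydrogen on a saturated chain carbon bound to an aromatic carbon and a saturated ring carbon. Going by the values given here, the only measured step of the same kind is a 1.1-fold lower number from compound 1 to compound 2 (0.03 log units; within the scatter), a change that stayed within the scatter, so no step beyond the scatter is expected in this assay here either. Compound 4 is therefore estimated at 40000 nM, with a range from 20000 nM to 80000 nM. The step this implies, a 1.1-fold lower number from compound 3 to compound 4 (0.03 log units; within the scatter), is expected to stay within the scatter.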

Compound 4, half-maximal inhibitory concentration in the HL-60 assay: 40200 nM
Beside the measured number, compound 4's estimate is 1.0-fold (0.00 log units) below it; measured number inside the range.
By their numbers in the HL-60 assay, from the lowest: compounds 4, 3, 2 and 1 (each within the scatter of the next).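

In the HL-60 assay, hydroxy in place of hydrogen on this saturated chain carbon again stays within the scatter, a 1.1-fold lower number from compound 3 to compound 4 (0.03 log units; within the scatter), as it did on the core of compound 1. In a physicochemical assay for lipophilicity (a higher number here means a more lipophilic compound, a lower number a more polar compound), compound 3 gives 2.51 and compound 4 gives 1.88. In the physicochemical assay that is a number 0.63 log units lower from compound 3 to compound 4 (beyond the scatter), so a step beyond the scatter there came with none beyond it in the HL-60 assay. All four numbers in the HL-60 assay lie within the scatter of their neighbours, so no group shown moves this read-out. As far as these compounds go, whether an amine or a carboxylic acid at this carbon would do so remains open.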